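From compound 2 to compound 4: a new arm

A few compounds are considered here, and "the series" means these few. Any claim that something is new, unique, unknown or untested is made for them only; others in the source may bear on it.

In a functional assay on U-937 cells (Homo sapiens) for cytotoxicity, read by MTT assay, with a stated time of 24 h (a lower number here means a stronger inhibitor, a higher number a weaker inhibitor), compound 2 `Nc1nn(Cc2cn(-c3ccc(O)c([N+](=O)[O-])c3)nn2)c2nc(-c3ccccc3)cc(C(F)(F)F)c12` gives 41.3 ug/mL, the lowest of three numbers, against compound 1 `Nc1nn(Cc2cn(-c3ccc(F)c(Cl)c3)nn2)c2nc(-c3ccccc3)cc(C(F)(F)F)c12` at 99.1 ug/mL and compound 3 `Nc1nn(Cc2cn(CC(=O)Nc3ccc(F)cc3Br)nn2)c2nc(-c3ccccc3)cc(C(F)(F)F)c12` at 98.3 ug/mL. Compound 4 `Nc1nn(Cc2cn(CC(=O)NC3CCCCC3)nn2)c2nc(-c3ccccc3)cc(C(F)(F)F)c12` has (cyclohexylcarbamoyl)methyl in place of 4-hydroxy-3-nitrophenyl on an aromatic nitrogen. Among the measured compounds shown here, the closest precedent is a 2.4-fold higher number from compound 2 to compound 3 (0.38 log units; beyond the scatter), modest, where ((2-bromo-4-fluorophenyl)carbamoyl)methyl enters at the same place. a 2.4-fold lower number from compound 1 to compound 2 (0.38 log units; beyond the scatter) is of the same size, while a 1.0-fold lower number from compound 1 to compound 3 (0.00 log units; within the scatter) is within the scatter. For the measured compounds named here, no measured compound carries the cyclohexyl ring, so the range stays wide. A modest upward move is expected, estimated as a 2.1-fold higher number from compound 2 to compound 4 (0.31 log units; beyond the scatter). The estimate for compound 4 is 85 ug/mL, with an expected range of 40 ug/mL to 170 ug/mL.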

Compound 4, half-maximal inhibitory concentration: 89 ug/mL
Estimate against measurement, compound 4: 1.0-fold (0.02 log units) below; low and high end bracket the measured number.
By their numbers in this assay, from the lowest: compound 2; then compounds 4, 3 and 1 (each within the scatter of the next).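

Notes on the series: in this assay, cyclohexyl on the amide-type nitrogen gives a 1.1-fold lower number from compound 3 to compound 4 (0.04 log units; within the scatter), so within the carbamoylmethyl arm, this non-aromatic ring and the 2-bromo-4-fluorophenyl ring cannot be told apart. Against the directly attached aryl groups, the new arm gives a 2.2-fold higher number from compound 2 to compound 4 (0.33 log units; beyond the scatter) and a 1.1-fold lower number from compound 1 to compound 4 (0.05 log units; within the scatter). Only compound 2 stands apart from the other three, so neither the arm nor the ring type alone sets the number.

No supporting data explain why the 4-hydroxy-3-nitrophenyl group stands apart. Open, as far as these compounds go, is whether an amine or carboxylic acid on the cyclohexyl ring, or a longer chain in the arm, would shift the number.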